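Cyano to 4-nitrophenyl: expected change in cytotoxicity

This account rests on a few compounds, and the source may have more. Where it says the series, first, only, none or still open, it means among the compounds named here.

Compound 1 `CCC1(Cc2ccccc2)OS(=O)(=O)C=C1OCC#N` gives in an ADME assay on HEL cells (Homo sapiens) for cytotoxicity, with a stated time of 3 days (a higher number here means that more compound is tolerated, a lower number that less compound is tolerated), only a limit, > 200000 nM, so compound 1 stands at the limit of > 200000 nM in this assay, at which 1 of the 3 values shown sits, without a number of its own. Compound 2 `CCC1(Cc2ccccc2)OS(=O)(=O)C=C1OS(=O)(=O)c1ccc(C)cc1` gives 109000 nM in this assay, and compound 3 `CC(C)CC1(Cc2ccccc2)OS(=O)(=O)C=C1OCc1ccccc1` gives 102000 nM. For the measured compounds named here, no step between measured compounds is defined in this set, so no measured step size is available. Compound 4 `CCC1(Cc2ccccc2)OS(=O)(=O)C=C1OCc1ccc([N+](=O)[O-])cc1` differs from compound 1 by 4-nitrophenyl in place of cyano on a saturated chain carbon bound to an oxygen on an unsaturated carbon. Because compound 2 gives 109000 nM and compound 3 gives 102000 nM, both carrying an aromatic ring on the same side of the core, a step toward a less tolerated compound, beyond the scatter, is expected: an at least 2.0-fold lower number from compound 1 to compound 4 (0.30 log units; that floor lies within the scatter). Compound 4 is accordingly estimated at 100000 nM, with a range from 40000 nM to 200000 nM.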

Compound 4, half-maximal cytotoxic concentration: < 200000 nM
Compound 4: no number, only a limit; the forecaster's own chance of this, stated with the estimate: 35%; the middle value does not contradict the limit.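

In this assay, 4-nitrophenyl in place of cyano on a saturated chain carbon bound to an oxygen on an unsaturated carbon gives a number no higher from compound 1 to compound 4 (the limit leaves the size open). Compound 4 gives < 200000 nM, which is a limit of the assay. Compound 1 gives > 200000 nM, also a limit, so this change shows a direction at this place but no readable size.

Left open is a number for compound 4 and thus the size of the step. Also open, going by these compounds, is whether an amine or a carboxylic acid at this place would keep compound 1's limit.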